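Swapping a bromine for a methoxy group on compound 1

The source may hold more compounds than are shown below. What is called first, only, known or untested is meant among the compounds shown, and "the series" means these compounds.

Compound 1 `COc1cc(C(=O)c2sc(-c3ccc(Br)cc3)cc2N)cc(OC)c1OC` is the weaker of the two measured compounds in a functional assay on CCRF-CEM cells (Homo sapiens) for antiproliferative activity (a higher number here means a weaker inhibitor, a lower number a stronger inhibitor), where compound 1 gives 86 nM. Among the compounds with values here, its only measured neighbour, compound 2 `COc1cccc(-c2cc(N)c(C(=O)c3cc(OC)c(OC)c(OC)c3)s2)c1`, gives 16 nM; the single measured step, 3-methoxyphenyl in place of 4-bromophenyl on an aromatic carbon, brings a 5.4-fold lower number from compound 1 to compound 2 (0.73 log units; beyond the scatter). Compound 3 `COc1ccc(-c2cc(N)c(C(=O)c3cc(OC)c(OC)c(OC)c3)s2)cc1` is not yet measured and differs from compound 1 by methoxy in place of bromo on an aromatic carbon. The step from compound 1 to compound 2 is the only one that bears on this change, and it exchanges the same bromine for a methoxy group, though placed differently on the six-membered ring. On that basis a modest move toward a lower number is expected for compound 3, a 2.9-fold lower number from compound 1 to compound 3 (0.46 log units; beyond the scatter), rather than a change within the scatter. Compound 3 is therefore estimated at 30 nM, within a range of 8 nM to 110 nM.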

Compound 3, half-maximal inhibitory concentration: 19 nM
Compound 3: middle estimate off by 1.6-fold (0.20 log units), on the high side, within the range that was stated.
By their numbers in this assay, from the lowest: compounds 2 and 3 (each within the scatter of the next); then compound 1.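

In this assay, methoxy in place of bromo at the same position gives a 4.5-fold lower number from compound 1 to compound 3 (0.66 log units; beyond the scatter) and so shows the change directly, without a shift of the group around the ring. The earlier step could not separate the exchange of bromine for methoxy from the change in placement. Comparing the two methoxy compounds, 4-methoxyphenyl in place of 3-methoxyphenyl gives a 1.2-fold higher number from compound 2 to compound 3 (0.07 log units; within the scatter), so these two placements cannot be told apart in this assay, and nothing shown here explains the difference between bromo and methoxy.

From the compounds shown here alone, whether a methyl group, an amine or a longer ether such as ethoxy would match methoxy at this position stays open. So does how a 3-bromophenyl group would compare with the 4-bromophenyl group of compound 1.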